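A few compounds are considered here, and "the series" means these few. Any claim that something is new, unique, unknown or untested is made for them only; others in the source may bear on it.

Measured so far:
compound 1, `CCNC(=O)[C@H]1OC(n2cnc3c(NC4CCCCC4)ncnc32)[C@H](O)[C@@H]1O`, 1.7 nM
compound 2, `CCNC(=O)[C@H]1OC(n2cnc3c(NC(CC)CC)ncnc32)[C@H](O)[C@@H]1O`, 1.5 nM

In an assay with adenosine receptor A1 (Rattus norvegicus) as the target (a lower number here means a stronger inhibitor, a higher number a weaker inhibitor), compound 1 gives the higher of these two numbers, but the step of a 1.1-fold lower number from compound 1 to compound 2 (0.05 log units; within the scatter) lies within the scatter, so the two are not distinguished. Compound 3, `O=C(O)[C@H]1OC(n2cnc3c(NC4CCCCC4)ncnc32)[C@H](O)[C@@H]1O`, differs from compound 1 in one place: hydroxy in place of ethylamino on a carbonyl carbon. Among the compounds with values here, the one measured step, from compound 1 to compound 2, changes a nitrogen on an aromatic ring and says nothing about the carbonyl carbon, so no measured step bears on this change. The account therefore rests on the structural change alone, and a large step toward weaker binding is expected, a 180-fold higher number from compound 1 to compound 3 (2.25 log units; beyond the scatter). For compound 3 the estimate is 300 nM, with a range from 30 nM to 3000 nM.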

Compound 3, half-maximal inhibitory concentration: 0.86 nM
Compound 3: the middle estimate sits 350-fold (2.54 log units) above what was measured, and the stated range ends above it.
By their numbers in this assay, from the lowest: compounds 3, 2 and 1 (each within the scatter of the next).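

In this assay the step of a 2.0-fold lower number from compound 1 to compound 3 (0.30 log units; within the scatter) shows that ethylamino and hydroxy on this carbonyl carbon are not distinguished, with the cyclohexyl group kept on the nitrogen. Within the data shown here, this is the first reading at this position, since the earlier pair differed only on the nitrogen. No evidence at hand accounts for this result. The compounds shown leave open how methylamino or methoxy on the same carbonyl carbon would read, and whether hydroxy in place of ethylamino would read the same with the pentan-3-yl group of compound 2.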